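Carboxymethyl for Bromo on the Aryl Ring

The source may report more compounds than this note shows. Statements on the series, on what has been measured and on what is new or still open speak of the compounds shown alone.

Among the measured compounds shown here, compound 2 `CC1CC/C(=N\Nc2ccc(Br)cc2)c2ncc(C(=O)O)c(=O)n21` gives 2000 nM in a functional assay (mast cells) for inhibition, with Rattus norvegicus as the target (on this read-out higher numbers stand for an effect only at larger amounts of compound and lower numbers for an effect already at smaller amounts), the lower of the two numbers so far, compound 1 `CC1CC/C(=N\Nc2cccc(Br)c2)c2ncc(C(=O)O)c(=O)n21` giving 6700 nM. For the measured compounds named here, the only measured step, a 3.4-fold lower number from compound 1 to compound 2 (0.53 log units; beyond the scatter), moves a bromo between ring positions and does not test a change of group. Compound 3 `CC1CC/C(=N\Nc2ccc(CC(=O)O)cc2)c2ncc(C(=O)O)c(=O)n21` differs from compound 2 by carboxymethyl in place of bromo on an aromatic carbon. Going by the values given here, with no step bearing on this exchange, compound 3 is expected to land near compound 2, at an estimated 3000 nM (range 800 nM to 12000 nM), a step of a 1.5-fold higher number from compound 2 to compound 3 (0.18 log units; within the scatter) that is expected to stay within the scatter.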

Compound 3, half-maximal effective concentration: 3400 nM
For compound 3 the middle estimate is 1.1-fold (0.05 log units) below the measured one; the measured number falls inside the stated range.
By their numbers in this assay, from the lowest: compounds 2, 3 and 1 (each within the scatter of the next, the first and the last beyond it).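

In this assay, among the compounds shown here, carboxymethyl in place of bromo on an aromatic carbon, para to a large group, gives a 1.7-fold higher number from compound 2 to compound 3 (0.23 log units; within the scatter), the first reading here of a change of group rather than a shift of bromo. At this position the two groups cannot be told apart, although the entering group has 4 heavy atoms against 1 and brings 1 hydrogen-bond donor and 1 hydrogen-bond acceptor. Nothing available accounts for this result. Going by these compounds, whether an amine or a longer chain ending in a carboxylic acid would also stay within the scatter of compound 2 remains open.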